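The compounds below may be only part of what the source reports. "The series", "measured", "known", "first", "only" and "open" are said of these compounds alone.

Compound 1 `Cc1cc(O)c(C2=NN(c3ccc(S(N)(=O)=O)cc3)C(c3ccccc3O)C2)cc1Cl` was tested in a functional assay on HCT-15 cells (Homo sapiens) for antiproliferative activity, with a stated time of 48 h (on this read-out higher numbers stand for lower toxicity in this test and lower numbers for higher toxicity in this test), and gave 44700 nM. Among the two results shown in this assay, compound 1 holds the only plain number; the other result is a limit of the assay. Compound 2 `Cc1cc(O)c(C2=NN(c3ccc(S(N)(=O)=O)cc3)C(/C=C/c3ccccc3)C2)cc1Cl` gives > 100000 nM in this assay, which is a limit and not a number, and it sits at the limit of > 100000 nM in this assay, at which 1 of the 2 values shown sits. The move from compound 1 to compound 2 replaces the 2-hydroxyphenyl on a saturated ring carbon by 2-phenylethenyl and gives an at least 2.2-fold higher number from compound 1 to compound 2 (0.34 log units; beyond the scatter).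

Compound 3 `COc1ccc(C2CC(c3cc(Cl)c(C)cc3O)=NN2c2ccc(S(N)(=O)=O)cc2)c(OC)c1OC` differs from compound 1 in the same place: 2,3,4-trimethoxyphenyl in place of 2-hydroxyphenyl on a saturated ring carbon. Going by the values given here, the only measured step that touches this carbon is the one from compound 1 to compound 2, and it removed the same 2-hydroxyphenyl with a rise in the number that went beyond the scatter, although what enters there is a different group. On that basis, a rise of similar size is expected for compound 3, written as a 1.6-fold higher number from compound 1 to compound 3 (0.19 log units; within the scatter). Compound 3 is therefore estimated at 70000 nM in this assay, expected to fall between 25000 nM and 200000 nM.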

Compound 3, concentration lethal to 50% of the cells: > 100000 nM
Compound 3 gave a limit, no number (the forecaster's own chance of this, stated with the estimate: 40%); middle value at least 1.4-fold (0.15 log units) from the limit.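

With compound 3, a six-membered aromatic ring stays on the saturated ring carbon, yet replacing 2-hydroxyphenyl with 2,3,4-trimethoxyphenyl still gives an at least 2.2-fold higher number from compound 1 to compound 3 (0.34 log units; beyond the scatter) in this assay. Going by these compounds alone, the rise seen earlier therefore does not depend on 2-phenylethenyl entering at this position: two different groups now move the number the same way, and no measured compound here goes against that. The result for compound 3 is a limit of the assay and not a number, like that of compound 2, so the step between these two cannot be read, and compound 1 remains the only one of the three with a plain number: the limit of > 100000 nM in this assay, at which 2 of the 3 values shown sit.

The compounds shown do not separate the loss of the hydroxyl from the addition of the three methoxy groups, since 2,3,4-trimethoxyphenyl differs from 2-hydroxyphenyl in both ways. From the compounds shown here alone, a phenyl ring with a single methoxy group, or with an amine in place of the hydroxyl, would help to show which of these matters, and whether any group at this carbon can bring the number below that of compound 1 also remains open.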